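Two Urea Analogues at the Assay Ceiling, a Third Awaiting

The source may report more compounds than this note shows. Statements on the series, on what has been measured and on what is new or still open speak of the compounds shown alone.

Measured compounds:
compound 1 `Cc1cc(NC(=O)Nc2ccc(C)c(Cl)c2)c2ccccc2n1`, > 25000 nM in an ADME assay on BJ cells (Homo sapiens) for cytotoxicity, with a stated time of 72 h; a lower number here means that less compound is needed, a higher number that more compound is needed for the effect
compound 2 `COc1ccc(NC(=O)Nc2cc(C)nc3ccccc23)cc1`, > 25000 nM in this assay

Compound 1 gives in this assay a reading of > 25000 nM, which is a limit of the assay and not a number. Compound 2 gives in this assay a reading of > 25000 nM, likewise a limit rather than a number. So compound 2 stands at the limit of > 25000 nM in this assay, at which 2 of the 2 values shown sit, and there is no measured step from it to any other compound.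

The unmeasured compound 3 `Cc1cc(NC(=O)Nc2ccc(C(=O)O)cc2)c2ccccc2n1` differs from compound 2 by carboxy in place of methoxy on an aromatic carbon.

Among the compounds with values here, with no measured step available, the expectation for compound 3 rests on the two limits alone. The account expects no step beyond the scatter from compound 2 to compound 3 in this assay, that is a step that the limit leaves unreadable from compound 2 to compound 3, and expects that compound 3 will most likely again return only a limit. The estimate for compound 3 in this assay is 30000 nM, within a range from 10000 nM to 100000 nM.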

Compound 3, half-maximal effective concentration: > 25000 nM
Compound 3: a limit, no number; the forecaster's own chance of this, stated with the estimate: 85%; the middle value does not contradict the limit.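

In this assay compound 3 gives > 25000 nM, which is a limit of the assay and not a number. Compound 2 also stands at a limit, so no step can be read between compound 2 and compound 3. The compounds shown leave open whether carboxy in place of methoxy changes the concentration needed for the effect at all.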